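The compounds below may be only part of what the source reports. "The series", "measured", "known", "first", "only" and "open" are said of these compounds alone.

Measured so far in an ADME assay on HepG2 cells (Homo sapiens) for cytotoxicity, read by luminescence, CellTiter-Glo and ATP content, with a stated time of 72 h; a higher number here means that more compound is needed for the effect, a lower number that less compound is needed:
- compound 1 `COc1ccc(F)cc1CNCCCNc1ccnc2cc(-c3ccc(F)cc3)ccc12`: 770 nM
- compound 2 `COc1ccc(F)cc1CNCCCNc1ccnc2cc(Oc3ccc(C(C)(C)C)cc3)ccc12`: 7200 nM
- compound 3 `COc1ccc(F)cc1CNCCCNc1ccnc2cc(CC(C)C)ccc12`: 2900 nM

Compound 3 stands second highest of the three numbers; compound 2 lies above it by a 2.5-fold lower number from compound 2 to compound 3 (0.39 log units; beyond the scatter) in the reverse direction, and compound 1 lies below it by a 3.8-fold higher number from compound 1 to compound 3 (0.58 log units; beyond the scatter) read backwards. The next compound is compound 4 `COc1ccc(F)cc1CNCCCNc1ccnc2cc(Oc3ccccc3OC)ccc12`, which differs from compound 3 by 2-methoxyphenoxy in place of isobutyl on an aromatic carbon.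

Among the measured compounds shown here, two measured steps bear on this change. The step from compound 2 to compound 3 exchanged an aryloxy group for isobutyl and gave a 2.5-fold lower number from compound 2 to compound 3 (0.39 log units; beyond the scatter); the step from compound 1 to compound 3 exchanged an aryl group for isobutyl and gave a 3.8-fold higher number from compound 1 to compound 3 (0.58 log units; beyond the scatter). Compound 4 brings back an aryloxy group, so the expected movement in this assay is a higher number, of a size between the two measured steps and closer to that seen for compound 2. The expected step is a 1.6-fold higher number from compound 3 to compound 4 (0.19 log units; within the scatter), giving an estimate for compound 4 of 4500 nM, with a range of 1500 nM to 14000 nM.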

Compound 4, half-maximal effective concentration: 6400 nM
Estimate against measurement, compound 4: 1.4-fold (0.15 log units) below; low and high end bracket the measured number.
By their numbers in this assay, from the lowest: compound 1; then compound 3; then compounds 4 and 2 (each within the scatter of the next).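

The exchange of isobutyl for 2-methoxyphenoxy on this aromatic carbon gives a 2.2-fold higher number from compound 3 to compound 4 (0.34 log units; beyond the scatter) in this assay, which is the reverse direction of the earlier move from 4-(tert-butyl)phenoxy to isobutyl and gives this position a second aryloxy example. Changing the aryl group on the oxygen gives a 1.1-fold lower number from compound 2 to compound 4 (0.05 log units; within the scatter), so 2-methoxyphenyl and 4-(tert-butyl)phenyl cannot be told apart here despite their different substituents. Both aryloxy compounds stand apart from the 4-fluorophenyl of compound 1, with an 8.3-fold higher number from compound 1 to compound 4 (0.92 log units; beyond the scatter) for the newest one, and no supporting data explain these shifts.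

Open, on these data alone, is whether the oxygen link itself matters, which 4-fluorophenoxy would test directly against compound 1. Also open, as far as these compounds go, is how an amine or a carboxylic acid at this position would read in this assay.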